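Fluoro to butyl: what compound 4 may show

This account rests on a few compounds, and the source may have more. Where it says the series, first, only, none or still open, it means among the compounds named here.

Measured in a functional assay on HT-29 cells (Homo sapiens) for antiproliferative activity, read by sulforhodamine B assay, with a stated time of 48 h; a higher number here means a weaker inhibitor, a lower number a stronger inhibitor:
Compound 1 `O=C1NCCN1c1ccc(S(=O)(=O)Nc2ccc(C3CCCCC3)cc2)cc1`: > 1000 nM (a limit)
Compound 2 `Cc1ccc(NS(=O)(=O)c2ccc(N3CCNC3=O)cc2)cc1`: 480 nM
Compound 3 `O=C1NCCN1c1ccc(S(=O)(=O)Nc2ccc(F)cc2)cc1`: 370 nM

Compound 3 at 370 nM and compound 2 at 480 nM lie within the scatter of each other. The entry for compound 1 is a limit. Compound 4 `CCCCc1ccc(NS(=O)(=O)c2ccc(N3CCNC3=O)cc2)cc1` differs from compound 3 by butyl in place of fluoro on an aromatic carbon. Butyl enters where cyclohexyl stood in compound 1. Among the compounds with values here, two steps bear on this, an at least 2.0-fold lower number from compound 1 to compound 2 (0.31 log units; beyond the scatter) and an at least 2.7-fold lower number from compound 1 to compound 3 (0.43 log units; beyond the scatter), both beyond the scatter, while a 1.3-fold lower number from compound 2 to compound 3 (0.11 log units; within the scatter) stays within it. Only compound 1 supports a rise, so a modest one is expected in this assay, an estimated 1.9-fold higher number from compound 3 to compound 4 (0.28 log units; within the scatter). For compound 4 the estimated value is 700 nM, with an expected range of 300 nM to 1600 nM.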

Compound 4, half-maximal inhibitory concentration: 610 nM
Compound 4: middle estimate off by 1.1-fold (0.06 log units), on the high side; low and high end bracket the measured number.
By their numbers in this assay, from the lowest: compounds 3, 2 and 4 (each within the scatter of the next). At a limit, above all of these: compound 1.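

In this assay, butyl on an aromatic carbon, para to a large group, stays within the scatter of the smaller groups: a 1.6-fold higher number from compound 3 to compound 4 (0.22 log units; within the scatter), and a 1.3-fold higher number from compound 2 to compound 4 (0.10 log units; within the scatter). An open chain of 4 carbon atoms at this position thus leaves the number level with fluoro and methyl. The remaining step, an at least 1.6-fold lower number from compound 1 to compound 4 (0.21 log units; that floor lies within the scatter), starts from a limit and not from a number: the limit of > 1000 nM in this assay, at which 1 of the 4 values shown sits.

On these data alone, whether butyl and cyclohexyl truly differ here stays open. So does what a longer chain, an amine or a carboxylic acid would give at this position.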